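A few compounds are considered here, and "the series" means these few. Any claim that something is new, unique, unknown or untested is made for them only; others in the source may bear on it.

Compound 1 `FC(F)(F)Oc1ccc(-c2cn(CC3=C(Cl)c4ccc(-c5cccs5)nc4CC3)nn2)cc1` and compound 2 `CCCCCc1cn(CC2=C(Cl)c3ccc(-c4cccs4)nc3CC2)nn1` share a core and differ only in the group on one aromatic carbon. In an ADME assay on MDCK cells (Canis lupus familiaris) for cytotoxicity, read by MTT assay, with a stated time of 48 h (a lower number here means that less compound is tolerated, a higher number that more compound is tolerated), compound 1 gives only a limit of the assay, > 300 ug/mL. In this assay, among the measured compounds shown here, compound 2 gives 50 ug/mL, the only actual number among the values shown. The measured step, an at least 6.0-fold lower number from compound 1 to compound 2 (0.77 log units; beyond the scatter), shows that exchanging the aromatic group for the chain lowered the number beyond the scatter, with the starting point being (the limit of > 300 ug/mL in this assay, at which 1 of the 2 values shown sits).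

Compound 3 `ClC1=C(Cn2cc(-c3ccsc3)nn2)CCc2nc(-c3cccs3)ccc21` is not yet measured. It differs from compound 2 as follows: thiophen-3-yl in place of pentyl on an aromatic carbon. For the measured compounds named here, this change runs opposite to the measured step, putting an aromatic ring back where the chain sat, though the ring is smaller than the one in compound 1. The step from compound 1 to compound 2 therefore bears on it, and a rise in the number for compound 3 is expected, possibly back to the limit. Compound 3 is expected to reach about 150 ug/mL in this assay, within 60 ug/mL to 300 ug/mL, which would mean an estimated step of a 3.0-fold higher number from compound 2 to compound 3 (0.48 log units; beyond the scatter).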

Compound 3, half-maximal cytotoxic concentration: > 300 ug/mL
Compound 3: only a limit was reported; the forecaster's own chance of this, stated with the estimate: 40%; at least 2.0-fold (0.30 log units) between middle value and limit.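

In this assay, thiophen-3-yl in place of pentyl on the same aromatic carbon of the five-membered ring with 3 nitrogen gives an at least 6.0-fold higher number from compound 2 to compound 3 (0.77 log units; beyond the scatter). Until now, 4-(trifluoromethoxy)phenyl was the only aromatic group shown at this carbon, so the lower number for compound 2 could have been specific to that one comparison, whereas compound 3 shows the same contrast with a second, different aromatic ring. Across these three compounds, the two with an aromatic ring on this carbon end at a limit and the one with the pentyl chain gives the only actual number, while the step from compound 1 to compound 3 cannot be read, since both of its ends are limits: the limit of > 300 ug/mL in this assay, at which 2 of the 3 values shown sit.

On these data alone, how far the tolerated amounts of compound 1 and compound 3 extend past that limit remains unknown, so these two rings cannot be ranked against each other. As far as these compounds go, it also remains open whether the lower number goes with the pentyl chain in particular or with non-aromatic groups more widely, a question that a shorter chain such as ethyl, a longer chain such as octyl, or a saturated ring such as cyclohexyl on this carbon could address.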